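A Shared Core, an Ester Added at the Chain

This account rests on a few compounds, and the source may have more. Where it says the series, first, only, none or still open, it means among the compounds named here.

Of the compounds shown here, three of one series have been measured in a functional assay on HT-29 cells (Homo sapiens) for cytotoxicity, read by MTT assay, with a stated time of 48 h; a lower number here means a stronger inhibitor, a higher number a weaker inhibitor. Compound 1 `CC(C)=CC[C@H](OC(=O)C=C(C)C)C1=CC(=O)c2c(O)ccc(O)c2C1=O` gives 800 nM. Compound 2 `COc1ccc(O)c2c1C(=O)C=C(CCC=C(C)C)C2=O` gives 5090 nM, and compound 3 `COc1ccc(O)c2c1C(=O)C(CCC=C(C)C)=CC2=O` gives 5980 nM. Compound 2 and compound 3 lie so close that repeated measurement could not tell them apart; compound 1 gives a clearly lower number, beyond the usual scatter, in this assay.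

The step of interest leads from compound 2 to compound 4 `COc1ccc(O)c2c1C(=O)C=C([C@H](CC=C(C)C)OC(=O)C=C(C)C)C2=O`, which has not yet been measured. The change is ((2-methylprop-1-en-1-yl)carbonyl)oxy in place of hydrogen on a saturated chain carbon bound to a double-bonded ring carbon and a saturated chain carbon. Within the data shown here, compound 1 carries the same ((2-methylprop-1-en-1-yl)carbonyl)oxy group on its chain, though on a differently substituted core, so the only guide is that compound 1 gives 800 nM while compound 2 gives 5090 nM. Taken with caution, a step to a lower number is expected, of a size that may just exceed the scatter, as a 2.3-fold lower number from compound 2 to compound 4 (0.36 log units; beyond the scatter). Compound 4 is therefore expected to give about 2200 nM, with a range from 700 nM to 6500 nM.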

Compound 4, half-maximal inhibitory concentration: 590 nM
For compound 4 the middle estimate is 3.7-fold (0.57 log units) above the measured one; the measured number lies below the stated range.
By their numbers in this assay, from the lowest: compounds 4 and 1 (each within the scatter of the next); then compounds 2 and 3 (each within the scatter of the next).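

In this assay, placing ((2-methylprop-1-en-1-yl)carbonyl)oxy in place of hydrogen on the saturated chain carbon gives an 8.6-fold lower number from compound 2 to compound 4 (0.94 log units; beyond the scatter), a direct reading of this change on a single core. The earlier compounds shown here could only hint at it, since compound 1 and compound 2 differ in more than one place. With this ester present, methyl in place of hydrogen on an oxygen on an aromatic ring gives a 1.4-fold lower number from compound 1 to compound 4 (0.13 log units; within the scatter), so these two compounds cannot be told apart in this measurement.

Still open, going by these compounds, is whether the whole ester matters or whether a smaller group on that carbon, such as a plain hydroxyl or an acetyl ester, would give a similar number. No measurement shown here explains the step.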